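Removing the Methoxy from the Aryl Ester

The source may hold more compounds than are shown below. What is called first, only, known or untested is meant among the compounds shown, and "the series" means these compounds.

In an ADME assay on cells (Hepatocyte, Homo sapiens) for metabolic stability, with a stated time of 30 min (a higher number here means that more of the compound is left, a lower number that less of the compound is left), compound 1 `O=C(OC1CCC(CN2CCN(c3cc(=O)c4cc(C(F)(F)F)cc([N+](=O)[O-])c4s3)CC2)CC1)C1CCCCC1` gives 2.8%.
Compound 2 `O=c1cc(N2CCN(CC3CCC(O)CC3)CC2)sc2c([N+](=O)[O-])cc(C(F)(F)F)cc12` gives 72.7%.
Compound 3 `COc1ccc(C(=O)OC2CCC(CN3CCN(c4cc(=O)c5cc(C(F)(F)F)cc([N+](=O)[O-])c5s4)CC3)CC2)cc1` gives 12.2%.

Compound 3 stands second highest of the three: the step of a number 9.4 percentage points higher from compound 1 to compound 3 (within the scatter) lies within the scatter, whereas a number 60.5 percentage points lower from compound 2 to compound 3 (beyond the scatter) is large. Compound 4 `O=C(OC1CCC(CN2CCN(c3cc(=O)c4cc(C(F)(F)F)cc([N+](=O)[O-])c4s3)CC2)CC1)c1ccccc1` differs from compound 3 by hydrogen in place of methoxy on an aromatic carbon, that is 4-methoxyphenyl to phenyl on the ester. Among the measured compounds shown here, only one measured step bears on this, the exchange of the acyl group in a number 9.4 percentage points higher from compound 1 to compound 3 (within the scatter), which stayed within the scatter; the large steps of a number 69.9 percentage points higher from compound 1 to compound 2 (beyond the scatter) and a number 60.5 percentage points lower from compound 2 to compound 3 (beyond the scatter) concern the ester against the free hydroxyl and do not apply. No step beyond the scatter is therefore expected in this assay. Compound 4 is estimated at 8%, between 1% and 25%, an expected a number 4.2 percentage points lower from compound 3 to compound 4 (within the scatter).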

Compound 4, percent of the compound remaining: 56.4%
Compound 4: middle estimate off by 48.4 percentage points, on the low side; measured number above the stated range.
By their numbers in this assay, from the lowest: compounds 1 and 3 (each within the scatter of the next); then compound 4; then compound 2.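

In this assay the acyl group of the ester proves far from indifferent, as hydrogen in place of methoxy on an aromatic carbon gives a number 44.2 percentage points higher from compound 3 to compound 4 (beyond the scatter), and phenyl in place of cyclohexyl on the carbonyl carbon gives a number 53.6 percentage points higher from compound 1 to compound 4 (beyond the scatter). An ester need not bring a large loss against the free hydroxyl, since the benzoyl group gives only a number 16.3 percentage points lower from compound 2 to compound 4 (beyond the scatter). No measurement at hand gives a cause for these steps. The compounds shown leave open whether a chlorine or an ethoxy on that aromatic carbon would read like hydrogen or like methoxy.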